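Hydroxyphenyl for dichlorophenyl on a purine-like core

The source may hold more compounds than are shown below. What is called first, only, known or untested is meant among the compounds shown, and "the series" means these compounds.

Measured compounds:
Compound 1 `CN1CCN(c2nc(-c3cccc(O)c3)nc3c2ncn3C)CC1` — 63.8%
Compound 2 `Cn1cnc2c(N3CCCCC3)nc(-c3cc(Cl)ccc3Cl)nc21` — 5.4%

In an assay on cells for displacement of a labelled ligand from adenosine receptor A3 (Homo sapiens), read by scintillation counting and radioligand binding, with a stated time of 180 min, tested at 10 uM (on this read-out lower numbers stand for less inhibition and higher numbers for more inhibition at the one concentration tested (going by the name of the read-out)), compound 2 gives 5.4%, the lower of the two numbers, with compound 1 standing well above it beyond the scatter. Compound 3 `Cn1cnc2c(N3CCCCC3)nc(-c3cccc(O)c3)nc21` is not yet measured. It differs from compound 2 by 3-hydroxyphenyl in place of 2,5-dichlorophenyl on an aromatic carbon. Going by the values given here, no measured pair shows this change alone, so its size is uncertain; since compound 1, which also carries the 3-hydroxyphenyl group, gives 63.8%, the step of a number 44.6 percentage points higher from compound 2 to compound 3 (beyond the scatter) is expected to be upward and sizeable. Compound 3 is estimated at 50%, within 20% to 80%.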

Compound 3, a percentage reported as inhibition, at one concentration (the size of the read-out at that concentration, not a potency): 49.1%
Beside the measured number, compound 3's estimate is 0.9 percentage points above it; measured number inside the range.
By their numbers in this assay, from the lowest: compound 2; then compound 3; then compound 1.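

In this assay, going by these compounds alone, 3-hydroxyphenyl in place of 2,5-dichlorophenyl gives a number 43.7 percentage points higher from compound 2 to compound 3 (beyond the scatter), the first reading of a change at this aromatic carbon alone, with piperidin-1-yl held fixed. The other position also matters, though less: piperidin-1-yl in place of 4-methylpiperazin-1-yl gives a number 14.7 percentage points lower from compound 1 to compound 3 (beyond the scatter), so the 3-hydroxyphenyl compounds remain separated by this exchange. Nothing measured here accounts for either step. The compounds shown leave open whether the rise follows the added hydroxyl or the loss of the two chlorines. Plain phenyl or 3-methoxyphenyl at this carbon would help separate the two.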